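From 4-hydroxyphenyl to 2,6-dimethoxyphenyl in a growth assay

The source may hold more compounds than are shown below. What is called first, only, known or untested is meant among the compounds shown, and "the series" means these compounds.

Of the compounds shown here, two sharing one core have been measured in a functional assay on RPMI-8226 cells (Homo sapiens) for inhibition, read by sulforhodamine B assay, with a stated time of 48 h; a higher number here means a weaker inhibitor of growth, a lower number a stronger inhibitor of growth. There, compound 1 `O=C(Cc1csc2nc(-c3ccc(Br)cc3)cn12)N/N=C/c1ccccc1` gives 7410 nM, and compound 2 `O=C(Cc1csc2nc(-c3ccc(Br)cc3)cn12)N/N=C/c1ccc(O)cc1` gives 4270 nM. The hydroxy in place of hydrogen on an aromatic carbon amounts to a 1.7-fold lower number from compound 1 to compound 2 (0.24 log units; within the scatter), so compound 2 stands level with compound 1 on the numbers available.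

Compound 3 `COc1cccc(OC)c1/C=N/NC(=O)Cc1csc2nc(-c3ccc(Br)cc3)cn12` is still unmeasured. Its difference is 2,6-dimethoxyphenyl in place of 4-hydroxyphenyl on a carbon with a double bond to nitrogen. Within the data shown here, only one measured step bears on this change, and only in part. It concerns the hydroxy that compound 3 no longer carries, and a 1.7-fold lower number from compound 1 to compound 2 (0.24 log units; within the scatter) shows no change beyond the scatter on adding that group. Among the measured compounds shown here, no measured compound carries a methoxy group, so the data say nothing directly about the entering substituent. No step beyond the scatter is therefore expected, in either direction. The expected change is a 1.2-fold higher number from compound 2 to compound 3 (0.07 log units; within the scatter). The estimate for compound 3 is 5000 nM, with an expected range from 1900 nM to 13000 nM.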

Compound 3, concentration for 50% growth inhibition: 10200 nM
Compound 3: middle estimate off by 2.0-fold (0.31 log units), on the low side; the measured number falls inside the stated range.
By their numbers in this assay, from the lowest: compounds 2, 1 and 3 (each within the scatter of the next, the first and the last beyond it).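

In this assay, among these compounds, the change from 4-hydroxyphenyl to 2,6-dimethoxyphenyl on a carbon with a double bond to nitrogen gives the first step beyond the scatter at this position (a 2.4-fold higher number from compound 2 to compound 3 (0.38 log units; beyond the scatter)), though a modest one, so the group held at this place can shift the number. The same entering group set against plain phenyl stays within the scatter (a 1.4-fold higher number from compound 1 to compound 3 (0.14 log units; within the scatter)), which means that 2,6-dimethoxyphenyl cannot be told apart from phenyl here and that only the two substituted groups stand apart from each other in this set. Nothing accompanying these numbers accounts for the step between them.

The step from compound 2 to compound 3 removes a hydroxy and brings in two methoxy groups in one move, so the compounds shown do not divide it between the group lost and the groups gained, a question that a single methoxy on the phenyl ring, as in 4-methoxyphenyl, would address directly. Also open is whether an amine or a carboxylic acid on this ring would move the number further than any group shown here.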